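Triazine series: sec-butylamino in place of diisopropylamino

The source may report more compounds than this note shows. Statements on the series, on what has been measured and on what is new or still open speak of the compounds shown alone.

Measured so far:
- compound 1, `CCN(CC)c1nc(Cl)nc(NC(C)c2ccccc2)n1`: 1510 nM
- compound 2, `CC(C)N(c1nc(Cl)nc(N[C@H](C)c2ccccc2)n1)C(C)C`: 6610 nM
- compound 3, `CC(C)N(c1nc(Cl)nc(N[C@@H](C)c2ccccc2)n1)C(C)C`: 110 nM

In an ADME assay on the whole organism for inhibition, with Echinochloa crus-galli var. formosensis as the target, with a stated time of 4 days (on this read-out lower numbers stand for stronger inhibition and higher numbers for weaker inhibition), compound 2 gives 6610 nM, the highest number of the three. Compound 1 gives 1510 nM, and compound 3 gives 110 nM. Going by the values given here, the one single-point step in the set is a 60-fold lower number from compound 2 to compound 3 (1.78 log units; beyond the scatter), which rests on the fact that compounds 2 and 3 differ only in the configuration as drawn alone and leaves the amino substituent untouched.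

Compound 4, `CC[C@H](C)Nc1nc(Cl)nc(N[C@H](C)c2ccccc2)n1`, keeps the configuration of compound 2 at the saturated chain carbon and changes ((sec-butyl)amino in place of diisopropylamino on an aromatic carbon). Among the compounds with values here, no measured step concerns this part of the shared core, and compounds 1 and 2 differ in more than one place, so their two values are all that can be read. The size of the step is therefore open. With the configuration of compound 2 retained, compound 4 is expected to stay in the same weak region, and the step of a 1.7-fold lower number from compound 2 to compound 4 (0.22 log units; within the scatter) is estimated to lie within the scatter. Compound 4 is estimated at 4000 nM in this assay, with a range from 900 nM to 18000 nM.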

Compound 4, half-maximal inhibitory concentration: 52500 nM
The estimate for compound 4 lay 13-fold (1.12 log units) below the measured number, and the stated range ends below it.
By their numbers in this assay, from the lowest: compound 3; then compound 1; then compound 2; then compound 4.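

Within this assay, (sec-butyl)amino in place of diisopropylamino gives a 7.9-fold higher number from compound 2 to compound 4 (0.90 log units; beyond the scatter), so the amino substituent on this aromatic carbon, left untouched in the earlier single-place step, also moves the number. With the chain-carbon configuration of compound 2 held, the number still rises, so that configuration does not alone set the level in this series. Nothing at hand accounts for the step, in which the group's size, its hydrogen-bond donor and its defined stereocentre all change together.

Open, on these data alone, is whether the same exchange gives a step of similar size with the chain-carbon configuration of compound 3, and what the opposite configuration within the sec-butyl group itself does. Also open, as far as these compounds go, is how a ring amine such as piperidine or morpholine, or a simple ethylamino group, behaves at this position.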